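The source may hold more compounds than are shown below. What is called first, only, known or untested is meant among the compounds shown, and "the series" means these compounds.

Measured compounds:
compound 1 `COc1ccc(CNc2nc3cc(N)cc(N)c3nc2-c2ccccc2)cc1OC`: < 100000 nM
compound 2 `COc1ccc(Sc2nc3cc(N)cc(N)c3nc2-c2ccccc2)cc1`: < 100000 nM

In a functional assay on SNB-19 cells (Homo sapiens) for inhibition, read by sulforhodamine B assay, with a stated time of 48 h (a lower number here means that less compound is tolerated, a higher number that more compound is tolerated), compound 1 gives < 100000 nM, which is a limit of the assay and not a number. Compound 2 gives < 100000 nM, likewise a limit. For the measured compounds named here, both measurements rest at the limit of < 100000 nM in this assay, at which 2 of the 2 values shown sit, so compound 2 stands at the same limit as compound 1, and no step between measured compounds can be read. Compound 3 `Nc1cc(N)c2nc(-c3ccccc3)c(Sc3ccc(F)cc3)nc2c1` differs from compound 2 by fluoro in place of methoxy on an aromatic carbon. With nothing measured to guide it, the step expected from compound 2 to compound 3 is a step that the limit leaves unreadable from compound 2 to compound 3, none beyond the scatter. Compound 3 is estimated at 60000 nM, ranging from 10000 nM to 200000 nM, and is expected most likely to be reported again as a limit.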

Compound 3, concentration lethal to 50% of the cells: 87100 nM
For compound 3 the middle estimate is 1.5-fold (0.16 log units) below the measured one, and the stated range covers the measured number.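

No step from compound 2 to compound 3 can be read, because the result for compound 2 is a limit and not a number: the limit of < 100000 nM in this assay, at which 2 of the 3 values shown sit.

The compounds shown leave open how fluoro and methoxy compare at this place.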